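Swapping the sulfonyl aryl group on a shared quinoline-free core

The compounds below may be only part of what the source reports. "The series", "measured", "known", "first", "only" and "open" are said of these compounds alone.

Compound 1 `Cc1ccc(S(=O)(=O)c2cnc3ccc(F)cc3c2N2CCC(C)CC2)cc1` gives 91% in an assay on isolated protein for displacement of a labelled ligand from metabotropic glutamate receptor 5 (Homo sapiens), with a stated time of 60 min, tested at 1 uM; on this read-out lower numbers stand for less inhibition and higher numbers for more inhibition at the one concentration tested (going by the name of the read-out).
Compound 2 `COc1ccc(S(=O)(=O)c2cnc3ccc(F)cc3c2N2CCC(C)CC2)cc1` gives 85% in this assay.
Compound 3 `CC1CCN(c2c(S(=O)(=O)c3ccc(F)c(F)c3)cnc3c(F)cccc23)CC1` gives 93% in this assay.

All three compounds share a core carrying a sulfonyl-linked aromatic ring and differ mainly in that ring or in the placement of fluorine on the core. Compound 3 shows the largest number of the three, yet its gaps to compound 1 and compound 2 both lie within the usual scatter of this assay, so no ranking among them can be read from these numbers.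

Compound 4 `CC1CCN(c2c(S(=O)(=O)c3ccc(Cl)cc3)cnc3c(F)cccc23)CC1` has not been measured. It differs from compound 3 in one place: 4-chlorophenyl in place of 3,4-difluorophenyl on a sulfonyl sulfur. Going by the values given here, the one measured step that concerns the same part of the molecule is a number 6 percentage points lower from compound 1 to compound 2 (within the scatter), a change of the group on the sulfonyl aryl ring that stayed within the scatter. On that basis a similar swap in compound 4 is expected to move the number little, if at all, with the step of a number 3 percentage points lower from compound 3 to compound 4 (within the scatter) being the expectation.

Compound 4 is therefore estimated to give 90% in this assay, with a likely range from 80% to 97%.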

Compound 4, a percentage reported as inhibition, at one concentration (the size of the read-out at that concentration, not a potency): 85%
The estimate for compound 4 lay 5 percentage points above the measured number, within the range that was stated.
By their numbers in this assay, from the lowest: compounds 2, 4, 1 and 3 (each within the scatter of the next).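

Replacing 3,4-difluorophenyl with 4-chlorophenyl on a sulfonyl sulfur gives a number 8 percentage points lower from compound 3 to compound 4 (within the scatter) in this assay, so this exchange of ring substituents cannot be told apart from repeat-to-repeat variation. Going by these compounds alone, the only earlier step at this part of the molecule, a number 6 percentage points lower from compound 1 to compound 2 (within the scatter), swapped methyl for methoxy on a different fluorine pattern on the core, so the new result extends the picture to a change in which halogen the ring carries and to the core of compound 3. Two separate swaps on the sulfonyl aryl ring have now stayed within the scatter, but no measurement here offers an explanation for either step.

The rings shown carry only methyl, methoxy, fluorine or chlorine, so it remains open whether a ring bearing an amine or a carboxylic acid, or a longer chain such as butyl, would keep inhibition at this level. Each number also comes from one tested concentration, so any differences in potency among these compounds remain open as well.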